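This account rests on a few compounds, and the source may have more. Where it says the series, first, only, none or still open, it means among the compounds named here.

Measured so far in a functional assay on QGY7701 cells (Homo sapiens) for cytotoxicity, read by MTT assay, with a stated time of 24 h; on this read-out lower numbers stand for stronger inhibition and higher numbers for weaker inhibition:

compound 1 `C=CC1=C(C(=O)NCc2ccccc2)C(c2ccc(Cl)c(Cl)c2)OC1`: > 100000 nM.
compound 2 `C=CC1=C(C(=O)Nc2ccc(C)cc2)C(c2ccc(F)cc2)OC1`: 59200 nM.
compound 3 `C=CC1=C(C(=O)Nc2ccc(C)cc2)C(c2ccc(OC)cc2)OC1`: > 100000 nM.

The result of compound 1 is a limit of the assay, not a number. The result of compound 3 is likewise a limit. Within the data shown here, compound 2 is therefore the only compound with a number, the other two sitting at the limit of > 100000 nM in this assay, at which 2 of the 3 values shown sit. Among the measured compounds shown here, the one step between measured compounds, an at least 1.6-fold higher number from compound 2 to compound 3 (0.22 log units; that floor lies within the scatter), concerns the ring bearing fluoro or methoxy and says nothing about the amide side of the molecule.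

Compound 4 `C=CC1=C(C(=O)Nc2ccccc2)C(c2ccc(F)cc2)OC1` differs from compound 2 by hydrogen in place of methyl on an aromatic carbon. For the measured compounds named here, no measured step touches that ring, so no change beyond the scatter is expected; the expected step is a 1.2-fold higher number from compound 2 to compound 4 (0.07 log units; within the scatter). Compound 4 is estimated at 70000 nM, between 25000 nM and 200000 nM.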

Compound 4, half-maximal inhibitory concentration: 46700 nM
Estimate against measurement, compound 4: 1.5-fold (0.18 log units) above; the measured number falls inside the stated range.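

Among these compounds, the change from 4-methylphenyl to phenyl is the first measured step on the amide side of the molecule, and in this assay it amounts to a 1.3-fold lower number from compound 2 to compound 4 (0.10 log units; within the scatter). With the fluoro-bearing ring held fixed, this methyl can therefore be replaced by hydrogen without a change that stands out from the scatter. This is also the only step that joins two actual numbers, as the other compounds stop at a limit: the limit of > 100000 nM in this assay, at which 2 of the 4 values shown sit.

On these data alone, what an amine or a carboxylic acid at this place on the ring would do remains open. So does whether the same result would hold with methoxy in place of fluoro.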